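This account rests on a few compounds, and the source may have more. Where it says the series, first, only, none or still open, it means among the compounds named here.

Of the compounds shown here, two have so far been measured in a physicochemical assay for lipophilicity; on this read-out lower numbers stand for lower lipophilicity and higher numbers for higher lipophilicity. Compound 1, `CSc1ccccc1C1=NC(c2ccccc2)CO1`, carries a methylsulfanyl group on its aromatic ring, while compound 2, `Cc1ccc(C2=NC(c3ccccc3)CO2)cc1`, carries a methyl group on a different carbon of that ring. In this assay compound 1 gives 3.5, the lower of the two numbers, and compound 2 gives 4.11, a gap that lies beyond the usual scatter. Because these two differ in more than one place, their values stand side by side without a step drawn between them.

Compound 3, `Brc1ccccc1C1=NC(c2ccccc2)CO1`, awaits measurement. It differs from compound 1 in one place: bromo in place of methylsulfanyl on an aromatic carbon. The bromo thus sits where the methylsulfanyl sat, on an aromatic carbon of a six-membered aromatic ring of carbon only, ortho to a large group. Among the measured compounds shown here, no measured pair shows how such a swap moves the number, so the expectation rests on compound 1, whose reading of 3.5 is the starting point. The expected change is a number 0.25 log units higher from compound 1 to compound 3 (within the scatter), a slight rise that may well stay within the scatter. Compound 3 is therefore estimated at 3.75, within a range from 3.35 to 4.15.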

Compound 3, partition coefficient: 3.69
Compound 3: the middle estimate sits 0.06 log units above what was measured; low and high end bracket the measured number.
By their numbers in this assay, from the lowest: compounds 1 and 3 (each within the scatter of the next); then compound 2.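

In this assay, among the compounds shown here, putting bromo in place of methylsulfanyl on an aromatic carbon, ortho to a large group, gives a number 0.19 log units higher from compound 1 to compound 3 (within the scatter), and this is the first step between two compounds that differ in one place only. Read with the usual scatter in mind, the step means that the two groups cannot be told apart on this read-out at this position, even though methylsulfanyl brings 2 heavy atoms, one of them sulfur, and 1 hydrogen-bond acceptor, whereas bromo brings 1 heavy atom and 0 hydrogen-bond acceptors. No measurement of any other kind bears on this result, so the data offer no explanation for the closeness of the two numbers.

A single pair cannot show whether the same swap would give a similar step on another carbon of this ring or on a different core. Nor do the compounds shown reveal how far the number would move if a group of a very different kind, such as an amine, a carboxylic acid or a longer alkyl chain, stood on this same aromatic carbon.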